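Trimming an Ethoxy Group to Methoxy on a Bcl-2 Inhibitor

The compounds below may be only part of what the source reports. "The series", "measured", "known", "first", "only" and "open" are said of these compounds alone.

Of the compounds shown here, three have been measured in an assay for inhibition of Apoptosis regulator Bcl-2 (Homo sapiens), read by fluorescence polarization, with a stated time of 2 h; on this read-out higher numbers stand for weaker inhibition and lower numbers for stronger inhibition. Compound 1 `CCCCn1c(C)c(C(=O)O)c(-c2cccc(N3CCN(c4ccc(NS(=O)(=O)c5ccc(N[C@H](CCN6CCC(O)CC6)CSc6ccccc6)c(S(=O)(=O)C(F)(F)F)c5)cc4)CC3)c2)c1-c1ccc(Cl)cc1` gives 78.2 nM, and compound 3 `Cc1c(C(=O)O)c(-c2cccc(N3CCN(c4ccc(NS(=O)(=O)c5ccc(N[C@H](CCN6CCC(C)(O)CC6)CSc6ccccc6)c(S(=O)(=O)C(F)(F)F)c5)cc4)CC3)c2)c(-c2ccc(Cl)cc2)n1C` gives 18.6 nM. Compound 2 `CCOc1cccc(S(=O)(=O)Nc2ccc(N3CCN(c4cccc(-c5c(C(=O)NCCCN6CCN(C)CC6)c(C)n(C)c5-c5ccc(Cl)cc5)c4)CC3)cc2)c1` gives 1620 nM, the highest of the three numbers; its gaps to compound 1 and to compound 3 both lie beyond the scatter of repeated measurements, so compound 2 is the weakest inhibitor of the three.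

Compound 4 `COc1cccc(S(=O)(=O)Nc2ccc(N3CCN(c4cccc(-c5c(C(=O)NCCCN6CCN(C)CC6)c(C)n(C)c5-c5ccc(Cl)cc5)c4)CC3)cc2)c1` has not yet been measured. It differs from compound 2 in one place only: hydrogen in place of methyl on a saturated chain carbon bound to an oxygen on an aromatic ring. Put simply, this is hydrogen in place of methyl on a saturated chain carbon bound to an oxygen on an aromatic ring, so that ethoxy becomes methoxy. Among the measured compounds shown here, no measured pair in this set shows what such a change does. With nothing measured to guide it, this small trimming is expected to shift the number by no more than the usual scatter, so the step of a 1.1-fold higher number from compound 2 to compound 4 (0.05 log units; within the scatter) is expected to be small. Compound 4 is therefore estimated at 1800 nM, within a range from 700 nM to 4500 nM.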

Compound 4, half-maximal inhibitory concentration: 802 nM
Beside the measured number, compound 4's estimate is 2.2-fold (0.35 log units) above it, and the stated range covers the measured number.
By their numbers in this assay, from the lowest: compound 3; then compound 1; then compound 4; then compound 2.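

In this assay, trimming ethoxy to methoxy gives a 2.0-fold lower number from compound 2 to compound 4 (0.31 log units; beyond the scatter) and so counts as a real, though modest, change. Among the compounds shown here, this is the only pair here that differs in one place, and it shows that the number responds to the loss of a single methyl group at this spot on the 3-ethoxyphenyl group, with the shorter methoxy giving the stronger inhibition of the two. No supporting measurement explains why the number moves.

Going by these compounds, two groups give a single step rather than a trend, so it remains open whether a longer propoxy chain, a hydroxyl group or a fluorine atom in the same place would continue or reverse it. On these data alone, whether this step would carry over to the core of compound 1 or compound 3 also remains open.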